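The compounds below may be only part of what the source reports. "The series", "measured", "known", "first", "only" and "open" are said of these compounds alone.

Working notes on the series. Compound 1 `O=C(NCc1ccc(F)cc1)c1nc(Br)c2cccnc2c1NCCCNc1c(C(=O)NCc2ccc(F)cc2)nc(Br)c2cccnc12` is a dimer of the shared core joined through a diamine linker; in a functional assay on MDA-MB-435 cells (Homo sapiens) for cytotoxicity, read by MTT assay, with a stated time of 72 h (on this read-out lower numbers stand for stronger inhibition and higher numbers for weaker inhibition), compound 1 reaches only the limit of the assay, > 20000 nM. Compound 3 `O=C(NCCCNc1c(C(=O)NCc2ccc(F)cc2)nc(Br)c2cccnc12)c1ccccc1` keeps one core and caps the linker with a benzamide; in this assay compound 3 also gives only a limit, > 20000 nM. Going by the values given here, compound 2 `N[C@H]1CC[C@H](Nc2c(C(=O)NCc3ccc(Oc4ccccc4)cc3)nc(Br)c3cccnc23)CC1` carries the trans-diaminocyclohexyl group on the core; in this assay compound 2 gives 4000 nM, the only real number in the set, the other two values sitting at the limit of > 20000 nM in this assay, at which 2 of the 3 values shown sit. Among the compounds with values here, no step between two measured compounds can be isolated, so the effect of any single change is untested here.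

Within the data shown here, compound 4 `CN(C)c1ccc(CNC(=O)c2nc(Br)c3cccnc3c2N[C@H]2CC[C@H](N)CC2)cc1` is the only unmeasured compound. It differs from compound 2 by dimethylamino in place of phenoxy on an aromatic carbon, with the diaminocyclohexyl group and the core unchanged. Among the measured compounds shown here, no measured pair shares this change. The direction can only be guessed from the size of what leaves and what enters. The step of a 1.6-fold higher number from compound 2 to compound 4 (0.21 log units; within the scatter) is expected to be small, toward weaker inhibition, and not clearly beyond the usual scatter. For compound 4 the estimated value in this assay is 6500 nM, with a range from 2500 nM to 20000 nM.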

Compound 4, half-maximal inhibitory concentration: 4000 nM
Compound 4: middle estimate off by 1.6-fold (0.21 log units), on the high side, within the range that was stated.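

In this assay, going by these compounds alone, phenoxy on the aromatic carbon para to a large group gives way to dimethylamino with no change at the digits printed from compound 2 to compound 4 (within the scatter), the first step that can be read at all. For this pair, the six-membered aromatic ring of carbon only that leaves with phenoxy is not needed to hold the value, and the smaller group with 3 heavy atoms serves equally well at this position, with compound 4 at 4000 nM as a real number and not a limit. No measurement shown explains why the two groups read alike, and this single flat step does not establish a rule for other groups at this position.

The compounds shown leave open whether the value would hold with a carboxylic acid or a morpholine group on this aromatic carbon, where the group entering differs more from both phenoxy and dimethylamino. No pair shown changes the diaminocyclohexyl group alone while keeping the rest, so its part in these values also stays open.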